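A few compounds are considered here, and "the series" means these few. Any claim that something is new, unique, unknown or untested is made for them only; others in the source may bear on it.

Of the compounds shown here, two have been tested so far in a functional assay on MDA-MB-361 cells (Homo sapiens) for antiproliferative activity, read by MTT assay, with a stated time of 72 h; on this read-out higher numbers stand for weaker inhibition and lower numbers for stronger inhibition. Compound 1, `O=C1NN=C(c2ccccc2)/C1=C/Nc1cc(-c2ccco2)[nH]n1`, gives 63700 nM in this assay. Compound 2, `CCOC(=O)c1c[nH]nc1N/C=C1\C(=O)N(c2ccccc2)N=C1c1ccccc1`, gives 24700 nM in this assay, the lower of the two numbers and the stronger inhibition, with compound 1 standing beyond the scatter above it.

Compound 3, `O=C1/C(=C\Nc2cc(-c3ccco3)[nH]n2)C(c2ccccc2)=NN1c1ccccc1`, has not yet been measured. It keeps the core of compound 2 and differs from it in one place: 5-(furan-2-yl)-1H-pyrazol-3-yl in place of 4-(ethoxycarbonyl)-1H-pyrazol-3-yl on an amine nitrogen. Among the measured compounds shown here, the group that enters is the same one that compound 1 carries, though compound 1 and compound 3 are not a matched pair and no step between them is given; their values simply show that the compound bearing this group so far has the higher number.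

For the measured compounds named here, no measured step isolates this exchange. With compound 1 at 63700 nM as the only point of reference for the entering group, compound 3 is expected to lose some potency relative to compound 2, a step of a 1.7-fold higher number from compound 2 to compound 3 (0.23 log units; within the scatter) that may still fall near the scatter. The estimate for compound 3 in this assay is 42000 nM, within a range from 15000 nM to 120000 nM.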

Compound 3, half-maximal inhibitory concentration: 13400 nM
Compound 3: middle estimate off by 3.1-fold (0.50 log units), on the high side; measured number below the stated range.
By their numbers in this assay, from the lowest: compounds 3 and 2 (each within the scatter of the next); then compound 1.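

In this assay, exchanging 4-(ethoxycarbonyl)-1H-pyrazol-3-yl for 5-(furan-2-yl)-1H-pyrazol-3-yl on an amine nitrogen gives a 1.8-fold lower number from compound 2 to compound 3 (0.27 log units; within the scatter), so with a phenyl on the amide-type nitrogen in the ring, this assay does not separate the two groups, even though they differ in ring content and in the count of hydrogen-bond acceptors. The result also gives the series its first step beyond the scatter: phenyl in place of hydrogen on the amide-type nitrogen in a ring gives a 4.8-fold lower number from compound 1 to compound 3 (0.68 log units; beyond the scatter), which shows that, with 5-(furan-2-yl)-1H-pyrazol-3-yl on the amine nitrogen, this second place has a modest effect on the read-out. Nothing at hand explains either step.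

Whether the phenyl step holds when 4-(ethoxycarbonyl)-1H-pyrazol-3-yl sits on the amine nitrogen remains open, since only one such pair is shown. Also open, going by these compounds, is how the read-out would respond to a carboxylic acid in place of the ethoxycarbonyl group, or to a benzyl group in place of the phenyl on the amide-type nitrogen.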